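Allyl for ethyl on two cores: cytotoxicity unchanged

The source may report more compounds than this note shows. Statements on the series, on what has been measured and on what is new or still open speak of the compounds shown alone.

In an ADME assay on TERT-RPE1 cells (Homo sapiens) for cytotoxicity, read by resazurin assay, with a stated time of 48 h (a higher number here means a weaker inhibitor, a lower number a stronger inhibitor), the four compounds fall into two pairs built on different cores. Compound 1 `CCN/C(SC)=C(/C#N)C(=O)Nc1ccc(OCC)cc1` and compound 2 `C=CCN/C(SC)=C(/C#N)C(=O)Nc1ccc(OCC)cc1` share one core; compound 3 `CCNc1[nH]nc2nnn(-c3ccc(OCC)cc3)c(=O)c12` and the unmeasured compound 4 `C=CCNc1[nH]nc2nnn(-c3ccc(OCC)cc3)c(=O)c12` share another. The difference between the two cores is not broken down here.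

In this assay compound 1 gives only a limit of the assay, > 100000 nM, and not a number. Compound 2 likewise reaches only the limit > 100000 nM. Compound 3 also stops at the limit > 100000 nM. Compound 2 differs from compound 1 by vinyl in place of methyl on a saturated chain carbon bound to an amine nitrogen; the step that the two limits leave unreadable from compound 1 to compound 2 cannot be read, since both ends of it are limits. The same kind of change, (vinyl in place of methyl on a saturated chain carbon bound to a nitrogen on an aromatic ring), leads from compound 3 to compound 4, but the place is not identical: in compound 1 the saturated chain carbon is bound to an amine nitrogen, whereas in compound 3 it is bound to a nitrogen on an aromatic ring.

For compound 4 a similar outcome is expected, a step of a number no higher from compound 3 to compound 4 (the limit leaves the size open), because compound 3 together with the other two measured compounds sits at the limit of > 100000 nM in this assay, at which 3 of the 3 values shown sit. Compound 4 is therefore estimated at 100000 nM, most likely again reported only as a limit, with an expected range from 50000 nM to 300000 nM.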

Compound 4, half-maximal inhibitory concentration: > 100000 nM
Compound 4: no number, only a limit (the forecaster's own chance of this, stated with the estimate: 90%); the middle value sits exactly at the limit.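

In this assay compound 4 gives > 100000 nM as a limit of the assay, not a number. No step can be read between compound 3 and compound 4, or between compound 1 and compound 2, because every end is a limit: the limit of > 100000 nM in this assay, at which 4 of the 4 values shown sit. The compounds shown leave open whether ethyl and allyl differ at all in cytotoxicity on either core.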